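A few compounds are considered here, and "the series" means these few. Any claim that something is new, unique, unknown or untested is made for them only; others in the source may bear on it.

Measured in a functional assay on B16 cells (Mus musculus) for cytotoxicity, read by MTT assay, with a stated time of 48 h; on this read-out higher numbers stand for weaker inhibition and lower numbers for stronger inhibition:
compound 1 `CCOC(=O)Cn1cc(-c2cccc(NC(=O)c3cn(Cc4ccccc4)nn3)c2)nn1`: 21000 nM
compound 2 `CCOC(=O)Cn1cc(C(=O)Nc2cccc(-c3cn(CC(=O)OCC)nn3)c2)nn1`: > 100000 nM, a limit
compound 3 `CCOC(=O)Cn1cc(C(=O)Nc2cccc(-c3cn(CCOC(C)=O)nn3)c2)nn1`: > 100000 nM, a limit

Compound 2 has no number of its own and stands at the limit of > 100000 nM in this assay, at which 2 of the 3 values shown sit. Compound 4 `CCOC(=O)Cn1cc(-c2cccc(NC(=O)c3cn(CCOC(C)=O)nn3)c2)nn1` has the same atoms joined differently: acetoxymethyl in place of ethoxycarbonyl on a saturated chain carbon bound to an aromatic nitrogen. Compound 3 carries the same exchange, but the step there gives no size: a step that the two limits leave unreadable from compound 2 to compound 3. Among the measured compounds shown here, the only step with a readable bound is an at least 4.7-fold higher number from compound 1 to compound 2 (0.67 log units; beyond the scatter), with ethoxycarbonyl in place of phenyl on a saturated chain carbon bound to an aromatic nitrogen. Compound 4 has no phenyl, so no step beyond the scatter is expected in this assay. For compound 4 the estimated value is 100000 nM, with an expected range of 40000 nM to 200000 nM.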

Compound 4, half-maximal inhibitory concentration: 63000 nM
The estimate for compound 4 lay 1.6-fold (0.20 log units) above the measured number, and the stated range covers the measured number.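

In this assay, a compound without the phenyl now carries a real number, so replacing phenyl on the saturated chain carbon bound to an aromatic nitrogen has a measured size: a 3.0-fold higher number from compound 1 to compound 4 (0.48 log units; beyond the scatter). Acetoxymethyl in place of ethoxycarbonyl gives an at least 1.5-fold lower number from compound 2 to compound 4 (0.20 log units; that floor lies within the scatter), so no change beyond the scatter can be claimed, and the step from compound 2 to compound 3 cannot be read. Compound 2 holds a limit, not a number: the limit of > 100000 nM in this assay, at which 2 of the 4 values shown sit. From the compounds shown here alone, it remains open how an amine or a carboxylic acid at this place would compare with phenyl.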